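Second Methyl on the Amide Nitrogen: What Compound 4 May Give

The source may report more compounds than this note shows. Statements on the series, on what has been measured and on what is new or still open speak of the compounds shown alone.

Three compounds share one core and differ only in the group hanging from the ether oxygen. Compound 1 `COCOc1cc(=O)oc2cc(OCc3cccc(Cl)c3)ccc12` carries a methoxy group there, and in an assay on isolated protein (strain Sprague-Dawley) for inhibition of Amine oxidase [flavin-containing] B (Rattus norvegicus), read by spectrophotometry, with a stated time of 5 min (on this read-out lower numbers stand for stronger inhibition and higher numbers for weaker inhibition), compound 1 gives 100 nM. Compound 2 `NC(=O)COc1cc(=O)oc2cc(OCc3cccc(Cl)c3)ccc12` carries a plain carbamoyl group; in this assay compound 2 gives 3.1 nM; 3.31 nM (2 entries), and the repeat entries the several entries of compound 2 in this assay, 3.1 nM; 3.31 nM (2 entries) show how closely this reading can be reproduced. Compound 3 `CNC(=O)COc1cc(=O)oc2cc(OCc3cccc(Cl)c3)ccc12` carries a methylcarbamoyl group and in this assay gives 33.9 nM, which is the lower of the two single numbers: the step of a 2.9-fold lower number from compound 1 to compound 3 (0.47 log units; beyond the scatter) is modest but real, while the entries of compound 2 sit at still lower numbers.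

Compound 4 `CN(C)C(=O)COc1cc(=O)oc2cc(OCc3cccc(Cl)c3)ccc12` adds a second methyl on the amide nitrogen: methyl in place of hydrogen on an amide-type nitrogen. Among the compounds with values here, no measured step covers this exact change. Within the data shown here, the only nearby comparison is the pair compound 2 and compound 3, where the first methyl on that nitrogen went with a clearly higher number. A second methyl is therefore expected to push the number higher again, a step estimated at a 4.4-fold higher number from compound 3 to compound 4 (0.65 log units; beyond the scatter). Compound 4 is expected to give about 150 nM in this assay, within a range from 40 nM to 600 nM.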

Compound 4, half-maximal inhibitory concentration: 501 nM
The estimate for compound 4 lay 3.3-fold (0.52 log units) below the measured number; the range from low to high includes it.
By their numbers in this assay, from the lowest: compound 3; then compound 1; then compound 4.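

Giving the amide-type nitrogen a second methyl proves costly in this assay, with a 15-fold higher number from compound 3 to compound 4 (1.17 log units; beyond the scatter) as a large step. The change also moves the side group past the methoxy of compound 1, since a 5.0-fold higher number from compound 1 to compound 4 (0.70 log units; beyond the scatter) sets the dimethylcarbamoyl group on the higher side of that compound, whereas the methylcarbamoyl group of compound 3 sits on the lower side. From plain carbamoyl to methylcarbamoyl to dimethylcarbamoyl, each added methyl goes with a higher number, and these gaps are far wider than the spread between repeat readings: the several entries of compound 2 in this assay, 3.1 nM; 3.31 nM (2 entries).

The compounds shown leave open whether a single ethyl on that nitrogen, or a morpholine amide, would follow the same trend. From the compounds shown here alone, how a carboxylic acid or an amine would compare in place of the amide is equally open.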